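A few compounds are considered here, and "the series" means these few. Any claim that something is new, unique, unknown or untested is made for them only; others in the source may bear on it.

The measured compounds and their values:

- Compound 1 `O=C(Nc1ccc(Br)cc1)c1c(NO)cc(-c2ccccc2)oc1=O`: in an ADME assay on Huh-7 cells (Homo sapiens) for cytotoxicity, read by a luciferase reporter and WST assay, with a stated time of 3 days (on this read-out lower numbers stand for higher toxicity in this test and higher numbers for lower toxicity in this test), compound 1 gives > 20000 nM, which is a limit of the assay and not a number.
- Compound 2 `O=C(Nc1ccc(O)cc1)c1c(NO)cc(-c2ccccc2)oc1=O`: compound 2 gives > 20000 nM, again a limit.
- Compound 3 `CCNC(=O)c1c(NO)cc(-c2ccccc2)oc1=O`: compound 3 gives > 20000 nM, also a limit.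

Compound 3 therefore stands where the whole small set stands: at the limit of > 20000 nM in this assay, at which 3 of the 3 values shown sit. For the measured compounds named here, no compound shows a number that would set it apart from the others, so no order among them can be read.

Compound 4 `O=C(NCc1ccccc1)c1c(NO)cc(-c2ccccc2)oc1=O` differs from compound 3 in one place: phenyl in place of methyl on a saturated chain carbon bound to an amide-type nitrogen. The closest measured steps are those that also alter the group on the amide-type nitrogen, a step that the two limits leave unreadable from compound 1 to compound 3 and a step that the two limits leave unreadable from compound 2 to compound 3, and the step on the aromatic ring, a step that the two limits leave unreadable from compound 1 to compound 2. All three sit between two limits, so none of them gives a readable size or direction. There is thus nothing in the measured data pointing to a change beyond the scatter for compound 4 in this assay.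

On that basis the step from compound 3 to compound 4 is expected to be a step that the limit leaves unreadable from compound 3 to compound 4, most likely again reported as a limit. The estimate for compound 4 is 30000 nM, with a range from 12000 nM to 100000 nM.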

Compound 4, half-maximal cytotoxic concentration: > 20000 nM
Compound 4 ended at the assay's limit; the forecaster's own chance of this, stated with the estimate: 85%; the middle value lies beyond the limit too.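

In this assay compound 4 gives > 20000 nM, which is a limit of the assay and not a number. The steps to compound 4 from compound 1, compound 2 and compound 3 therefore cannot be read, and all four compounds stand together: the limit of > 20000 nM in this assay, at which 4 of the 4 values shown sit. The compounds shown leave open whether changing the group on the amide-type nitrogen alters toxicity in this assay at all.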